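Methoxy for ethyl on the fused core of compound 3

The compounds below may be only part of what the source reports. "The series", "measured", "known", "first", "only" and "open" are said of these compounds alone.

Three compounds share a fused bicyclic core carrying a hydroxyl and a benzyl group. Compound 1 `Cc1nn2c(O)cc(C3CCOCC3)nc2c1Cc1cccc(C(F)(F)F)c1C` gives 10000 nM in an assay on MDA-MB-468 cells for inhibition of phosphatidylinositol 4,5-bisphosphate 3-kinase catalytic subunit beta isoform (Homo sapiens), in the presence of a further agent that is not named here; on this read-out higher numbers stand for an effect only at larger amounts of compound and lower numbers for an effect already at smaller amounts. Compound 2 `Cc1c(Cc2cnn3c(O)cc(-c4ccncc4)nc23)cccc1C(F)(F)F` gives 3160 nM in this assay. Compound 3 `CCc1nn2c(O)cc(-c3ccncc3)nc2c1Cc1cccc(Cl)c1Cl` gives 20000 nM in this assay. The numbers of compound 3 and compound 1 lie within the scatter of each other, so no order is read between them. Going by the values given here, the number of compound 3 is separated from that of compound 2 by a gap beyond the scatter, compound 2 being the one with the lower number. Among the compounds with values here, no pair among the three differs in only one place, so no single-step comparison is available.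

Compound 4 `COc1nn2c(O)cc(-c3ccncc3)nc2c1Cc1cccc(Cl)c1Cl` carries methoxy in place of ethyl on an aromatic carbon. Within the data shown here, the three measured compounds give no example of such a change, and an ethyl-to-methoxy exchange at this position is uncharted here. The step from compound 3 to compound 4 is expected to be small, with no direction beyond the scatter, and is estimated as a 1.3-fold lower number from compound 3 to compound 4 (0.12 log units; within the scatter). For compound 4 in this assay a value of 15000 nM is expected, with a plausible range from 5000 nM to 40000 nM. Given the high numbers of the series, a report of only a limit is a real possibility.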

Compound 4, half-maximal effective concentration: 12600 nM
Beside the measured number, compound 4's estimate is 1.2-fold (0.08 log units) above it; the range from low to high includes it.
By their numbers in this assay, from the lowest: compound 2; then compounds 1, 4 and 3 (each within the scatter of the next).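

In this assay, the series gains its first comparison that differs in one place: methoxy in place of ethyl on an aromatic carbon of the five-membered aromatic ring with 2 nitrogen, which gives a 1.6-fold lower number from compound 3 to compound 4 (0.20 log units; within the scatter). The exchange puts an oxygen into the chain and adds one hydrogen-bond acceptor while the count of 2 heavy atoms stays the same, yet the read-out of compound 4 cannot be separated from that of compound 3, so this pair shows no measurable consequence of the change at this position. No measurement bearing on the origin of this outcome is available, and the added acceptor therefore cannot be assigned any role.

As far as these compounds go, whether a group of another kind at this carbon, such as an amine or a longer chain like propoxy, would give a step beyond the scatter remains open. This single pair also leaves open whether methoxy in place of ethyl reads the same when the 2,3-dichlorobenzyl group on the shared core is replaced by another benzyl group.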